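This account rests on a few compounds, and the source may have more. Where it says the series, first, only, none or still open, it means among the compounds named here.

Compound 1 `O=C(CSc1ncccn1)N/N=c1/scc(-c2ccc([N+](=O)[O-])cc2)n1-c1ccccc1` was tested in an ADME assay on NIH3T3 cells (Mus musculus) for cytotoxicity, read by MTT assay, with a stated time of 24 h (a higher number here means a weaker inhibitor, a lower number a stronger inhibitor), where compound 1 gives 193 ug/mL. Among the two numbers measured so far compound 1 stands at the top, but only by a gap that lies within the scatter: its nearest neighbour, compound 2 `O=C(CSc1ncccn1)N/N=c1/scc(-c2ccccc2)n1-c1ccccc1`, gives in this assay a value of 107 ug/mL. Among the compounds with values here, the single measured step between them, a 1.8-fold lower number from compound 1 to compound 2 (0.26 log units; within the scatter), puts hydrogen in place of nitro on an aromatic carbon and does not move the read-out beyond the scatter.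

Compound 3 `Cn1nnnc1SCC(=O)N/N=c1/scc(-c2ccc([N+](=O)[O-])cc2)n1-c1ccccc1` has not yet been measured. It differs from compound 1 in one place: 1-methyl-1H-tetrazol-5-yl in place of pyrimidin-2-yl on a sulfur. The rest of the shared core, including the nitro group, is kept. Within the data shown here, no measured step touches the group on that sulfur, so the two numbers in hand say nothing about the direction such a swap might take. Among the measured compounds shown here, the one known step, a 1.8-fold lower number from compound 1 to compound 2 (0.26 log units; within the scatter), concerns another part of the molecule and is itself within the scatter. The expected step is therefore a 1.1-fold lower number from compound 1 to compound 3 (0.03 log units; within the scatter), meaning no change beyond the scatter. Compound 3 is thus estimated at 180 ug/mL, within a range from 90 ug/mL to 360 ug/mL.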

Compound 3, half-maximal inhibitory concentration: 167 ug/mL
For compound 3 the middle estimate is 1.1-fold (0.03 log units) above the measured one, and the stated range covers the measured number.
By their numbers in this assay, from the lowest: compounds 2, 3 and 1 (each within the scatter of the next).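

The earlier pair left the group on the sulfur untouched, and here changing it from pyrimidin-2-yl to 1-methyl-1H-tetrazol-5-yl gives a 1.2-fold lower number from compound 1 to compound 3 (0.06 log units; within the scatter). So in this assay a six-membered aromatic ring with 2 hetero atoms and a five-membered aromatic ring with 4 hetero atoms, each with 6 heavy atoms, give read-outs that cannot be told apart, and this one exchange on the sulfur shows no change beyond the scatter. Nothing at hand explains this result or connects it to any property of either group.

From the compounds shown here alone, all three compounds carry an aromatic ring of the same heavy-atom count on that sulfur, so it remains open whether a quite different group there, such as a saturated chain ending in an amine or in a carboxylic acid, would move the number beyond the scatter. Also open, going by these compounds, is how 1-methyl-1H-tetrazol-5-yl on the sulfur would read in combination with hydrogen in place of nitro on the aromatic carbon, the other change seen in this small set.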